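A few compounds are considered here, and "the series" means these few. Any claim that something is new, unique, unknown or untested is made for them only; others in the source may bear on it.

Three close relatives of one chemical family have been tested, and a fourth awaits its result. Compound 1 `NC(=O)CC[C@H](NC(=O)CN(c1nc(Cl)nc2[nH]cnc12)C1CC1)C(=O)OCc1ccccc1`, compound 2 `CC(C)C[C@H](NC(=O)CN(c1nc(Cl)nc2[nH]cnc12)C1CC1)C(=O)OCc1ccccc1` and compound 3 `CC(C)C[C@H](NC(=O)CN(c1nc(Cl)nc2[nH]cnc12)C1CC1)C(=O)O` share a core and differ in two respects. In a functional assay on the whole organism (Tail, strain ICR) with Mus musculus as the target, in the tail flick test, with a stated time of 60 min, at a dose of 25 umol/kg by the oral route (on this read-out higher numbers stand for a stronger effect at the one dose given and lower numbers for a weaker effect), compound 1 gives 33.1%, compound 2 gives 27.3% and compound 3 gives 36.4%. Two steps can be read between them. Compound 1 differs from compound 2 by carbamoylmethyl in place of isopropyl on a saturated chain carbon, two bonds along the chain from an amide-type nitrogen and a carbonyl carbon, and the read-out moved a number 5.8 percentage points higher from compound 2 to compound 1 (within the scatter). Compound 3 differs from compound 2 by hydrogen in place of benzyl on an oxygen next to a carbonyl group, and the read-out moved a number 9.1 percentage points higher from compound 2 to compound 3 (within the scatter). Neither step is large enough to stand out from the usual scatter of repeated measurements, so the three compounds cannot be ranked against each other.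

Compound 4 `NC(=O)CC[C@H](NC(=O)CN(c1nc(Cl)nc2[nH]cnc12)C1CC1)C(=O)O` has not yet been measured in this assay. It differs from compound 3 by carbamoylmethyl in place of isopropyl on a saturated chain carbon, two bonds along the chain from an amide-type nitrogen and a carbonyl carbon, the same change already made from compound 2 to compound 1, at a place described in the same words. The two starting cores differ from each other by hydrogen in place of benzyl on an oxygen next to a carbonyl group. Because the earlier step of a number 5.8 percentage points higher from compound 2 to compound 1 (within the scatter) stayed within the scatter, the step now expected is a number 3.6 percentage points higher from compound 3 to compound 4 (within the scatter). Compound 4 is thus estimated at 40%, with the value expected to fall between 28% and 52%.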

Compound 4, a percentage reported as activity, at one dose (the size of the read-out at that dose, not a potency): 38.4%
Estimate against measurement, compound 4: 1.6 percentage points above; measured number inside the range.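

In this assay, placing carbamoylmethyl where isopropyl stood on the acid core moved the read-out a number 2 percentage points higher from compound 3 to compound 4 (within the scatter), and this change looks the same on the two cores as far as these numbers can tell: the same change on two cores in this assay, a number 5.8 percentage points higher (within the scatter) from compound 2 to compound 1 and a number 2 percentage points higher (within the scatter) from compound 3 to compound 4, 3.8 percentage points apart, within the scatter of two such steps. Replacing benzyl with hydrogen on the oxygen of the glutamine-type compounds moved the read-out a number 5.3 percentage points higher from compound 1 to compound 4 (within the scatter), and that change also reads alike on both cores: the same change on two cores in this assay, a number 9.1 percentage points higher (within the scatter) from compound 2 to compound 3 and a number 5.3 percentage points higher (within the scatter) from compound 1 to compound 4, 3.8 percentage points apart, within the scatter of two such steps. So the four compounds give no sign that either change behaves differently from one core to the other, but they do not show that either change has a real effect, and agreement between steps this small, each within the usual scatter, says little about how reliably a change carries over.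

What the compounds shown leave open is what other groups would do at these two places, for example an amine or a longer chain on the saturated chain carbon, or a methyl ester in place of the benzyl ester. As far as these compounds go, it also remains open whether these compounds would separate from one another in this assay at a dose other than the single one given.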